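This account rests on a few compounds, and the source may have more. Where it says the series, first, only, none or still open, it means among the compounds named here.

Notes on the series, read in a functional assay on PC-3 cells (Homo sapiens) for inhibition, read by MTT assay, with a stated time of 48 h; on this read-out higher numbers stand for weaker inhibition and lower numbers for stronger inhibition. Compound 1 `Cc1ccc(/C=C2\SC(=O)N(CC(=O)Nc3c(C)n(C)n(-c4ccccc4)c3=O)C2=O)cc1`, with methyl on the aromatic ring, gives 45300 nM. Compound 2 `COc1ccc(/C=C2\SC(=O)N(CC(=O)Nc3c(C)n(C)n(-c4ccccc4)c3=O)C2=O)cc1`, with methoxy in place of methyl, gives 93700 nM. Compound 3 `Cc1c(NC(=O)CN2C(=O)S/C(=C\c3ccc([N+](=O)[O-])cc3)C2=O)c(=O)n(-c2ccccc2)n1C`, with nitro at that place, reads > 100000 nM, which is a limit of the assay and not a number. Its standing is known only as the limit of > 100000 nM in this assay, at which 1 of the 3 values shown sits.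

Compound 4 `Cc1c(NC(=O)CN2C(=O)S/C(=C\c3ccc(Br)cc3)C2=O)c(=O)n(-c2ccccc2)n1C` takes bromo in place of nitro on an aromatic carbon, para to a large group: bromo in place of nitro on an aromatic carbon. Three measured steps at this place bear on the change. The first is modest, a 2.1-fold higher number from compound 1 to compound 2 (0.32 log units; beyond the scatter). The second is at least modest, an at least 2.2-fold higher number from compound 1 to compound 3 (0.34 log units; beyond the scatter). The third gives only a floor that lies within the scatter, an at least 1.0-fold higher number from compound 2 to compound 3 (0.02 log units; that floor lies within the scatter).

Among the compounds with values here, no measured step involves bromo, and the start of this step has no number, so its size stays loose. Within the data shown here, the only numbers at this place are compound 1 at 45300 nM and compound 2 at 93700 nM, and a value near these is expected. A modest move toward a lower number is therefore expected, with the expected step being an at least 1.6-fold lower number from compound 3 to compound 4 (0.22 log units; that floor lies within the scatter). The estimate for compound 4 is 60000 nM, with an expected range of 25000 nM to 100000 nM.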

Compound 4, half-maximal inhibitory concentration: 17100 nM
Compound 4: the middle estimate sits 3.5-fold (0.55 log units) above what was measured, outside the stated range (below it).
By their numbers in this assay, from the lowest: compound 4; then compound 1; then compound 2. At a limit, above all of these: compound 3.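

In this assay, within the data shown here, bromo on an aromatic carbon, para to a large group, is the first change at this place to bring the number down from methyl, giving a 2.6-fold lower number from compound 1 to compound 4 (0.42 log units; beyond the scatter) and making compound 4 the lowest of the four values. Among these compounds, the distance from methoxy is wider, at a 5.5-fold lower number from compound 2 to compound 4 (0.74 log units; beyond the scatter) in the same direction, so the place spans more of the read-out than the earlier compounds showed, and the earlier steps, all upward from methyl, gave no sign of a move downward. The step from nitro, an at least 5.8-fold lower number from compound 3 to compound 4 (0.76 log units; beyond the scatter), is only a floor, since compound 3 stands at a limit of the assay and not at a number: the limit of > 100000 nM in this assay, at which 1 of the 4 values shown sits.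

The four groups show an order at this one place, but they do not tell whether chloro or iodo would follow bromo, or whether an amine or a carboxylic acid would fall within the same span. As far as these compounds go, whether bromo keeps its standing at another carbon of this ring, or with a different group on the rest of the shared core, also stays open.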